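The compounds below may be only part of what the source reports. "The series", "measured", "known", "first", "only" and "open" are said of these compounds alone.

Measured compounds:
Compound 1, `CN1CCN(C[C@H]2CN(c3ccc(-n4cc(-c5ccccn5)cn4)c(F)c3)C(=O)O2)CC1`, in a physicochemical assay for solubility, read by HPLC, with a stated time of 24 h (on this read-out higher numbers stand for higher solubility and lower numbers for lower solubility), gives 1690000 nM.
Compound 2, `O=C(OC[C@H]1CN(c2ccc(-n3cc(-c4ccccn4)cn3)c(F)c2)C(=O)O1)c1ccccc1`, in this assay sits at a limit of the assay, <= 65400 nM.
Compound 3, `O=C1O[C@@H](Cn2ccnc2)CN1c1ccc(-n2cc(-c3ccccn3)cn2)c(F)c1`, in this assay gives 12300 nM.

Among the readable numbers compound 3 holds the lowest; the nearest is compound 1, separated by a 140-fold lower number from compound 1 to compound 3 (2.14 log units; beyond the scatter). Compound 4, `CONC(=O)[C@H]1CN(c2ccc(-n3cc(-c4ccccn4)cn3)c(F)c2)C(=O)O1`, differs from compound 3 by methoxycarbamoyl in place of (1H-imidazol-1-yl)methyl on a saturated ring carbon. Within the data shown here, no measured step exchanges the (1H-imidazol-1-yl)methyl group for anything comparable: an at least 25-fold lower number from compound 1 to compound 2 (1.41 log units; beyond the scatter) and a 140-fold lower number from compound 1 to compound 3 (2.14 log units; beyond the scatter) both replace 4-methylpiperazin-1-yl, and a step that the limit leaves unreadable from compound 2 to compound 3 cannot be read because of the limit of <= 65400 nM in this assay, at which 1 of the 3 values shown sits. The account therefore expects no step beyond the scatter, a 1.6-fold higher number from compound 3 to compound 4 (0.21 log units; within the scatter). Compound 4 is estimated at 20000 nM, with a range from 5000 nM to 80000 nM.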

Compound 4, solubility: 78100 nM
Beside the measured number, compound 4's estimate is 3.9-fold (0.59 log units) below it; the measured number falls inside the stated range.
By their numbers in this assay, from the lowest: compound 3; then compound 4; then compound 1.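

In this assay, among these compounds, methoxycarbamoyl in place of (1H-imidazol-1-yl)methyl on this saturated ring carbon, next to the ring oxygen, gives the first readable step here that does not start from compound 1: a 6.3-fold higher number from compound 3 to compound 4 (0.80 log units; beyond the scatter). (4-Methylpiperazin-1-yl)methyl still keeps the highest number, with a 22-fold lower number from compound 1 to compound 4 (1.34 log units; beyond the scatter). The remaining new step, an at least 1.1-fold higher number from compound 2 to compound 4 (0.07 log units; that floor lies within the scatter), rests on a limit of the assay and gives only a floor: the limit of <= 65400 nM in this assay, at which 1 of the 4 values shown sits.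

Where a primary amine or a carboxylic acid on this carbon would fall in this assay remains open.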